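Swapping the chloropyridinylmethyl group for benzyl in a hydrazone series

The source may hold more compounds than are shown below. What is called first, only, known or untested is meant among the compounds shown, and "the series" means these compounds.

Measured so far:
- Compound 1 `O=C(N/N=C/c1ccco1)c1cc(-c2ccccc2)nn1Cc1ccccc1`: "not determined" (no result reported) in a functional assay on A549 cells (Homo sapiens) for cytotoxicity, read by MTT assay, with a stated time of 96 h; a lower number here means a stronger inhibitor, a higher number a weaker inhibitor
- Compound 2 `O=C(N/N=C/c1ccccc1O)c1cc(-c2ccccc2)nn1Cc1ccc(Cl)nc1`: 5830 nM
- Compound 3 `O=C(N/N=C/c1ccccc1O)c1cc(-c2ccc(Cl)cc2)nn1Cc1ccc(Cl)nc1`: 3680 nM

Among the compounds with values here, compound 2 stands at the highest of the two numbers given, with compound 3 its only neighbour. Within the data shown here, the step of a 1.6-fold lower number from compound 2 to compound 3 (0.20 log units; within the scatter) is the sole measured comparison, and it lies within the scatter, so the two compounds read as equivalent here.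

Compound 4 `O=C(N/N=C/c1ccccc1O)c1cc(-c2ccccc2)nn1Cc1ccccc1` differs from compound 2 by phenyl in place of 6-chloropyridin-3-yl on a saturated chain carbon bound to an aromatic nitrogen. Among the measured compounds shown here, no measured pair addresses this exchange: the single step in hand concerns a different ring, and compound 1, which carries the benzyl group, has no number in this assay. The expectation for compound 4 therefore rests on compound 2 alone, and the author expects a step of a 1.0-fold higher number from compound 2 to compound 4 (0.01 log units; within the scatter) that is not beyond the scatter, in either direction. Compound 4 is estimated at 6000 nM, with a range of 2000 nM to 18000 nM to reflect the absence of any directly relevant step.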

Compound 4, half-maximal inhibitory concentration: 10800 nM
Beside the measured number, compound 4's estimate is 1.8-fold (0.26 log units) below it, and the stated range covers the measured number.
By their numbers in this assay, from the lowest: compounds 3, 2 and 4 (each within the scatter of the next, the first and the last beyond it).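

Within the data shown here, at the place described as a saturated chain carbon bound to an aromatic nitrogen, the exchange of (6-chloropyridin-3-yl)methyl for benzyl gives the only measured reading in this assay (a 1.9-fold higher number from compound 2 to compound 4 (0.27 log units; within the scatter)). The step lies within the scatter, so this pair reads as equivalent, and in this one comparison phenyl can stand in place of 6-chloropyridin-3-yl without a difference that the assay can separate from repeat variation. Nothing at hand bears on the cause of this result.

From the compounds shown here alone, the reading rests on a single pair, so it remains open whether benzyl would read the same alongside the chloro substituent of compound 3. Also open, going by these compounds, is how an amine, a carboxylic acid or a longer chain would read at this same place.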